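Changing the Side Chain of Compound 2

The source may hold more compounds than are shown below. What is called first, only, known or untested is meant among the compounds shown, and "the series" means these compounds.

Measured so far in a toxicity assay on L02 cells (Homo sapiens) for cytotoxicity, read by MTT assay, with a stated time of 72 h; on this read-out lower numbers stand for stronger inhibition and higher numbers for weaker inhibition:
compound 1 `CC1(C)OCC(Cn2cc(Cn3c4c(c5ccccc53)C(=O)c3c[n+]([O-])c5ccccc5c3C4=O)nn2)O1` gives 120 nM
compound 2 `CN1CCN(CCCCn2c3c(c4ccccc42)C(=O)c2c[n+]([O-])c4ccccc4c2C3=O)CC1` gives 80 nM
compound 3 `O=C1c2c[n+]([O-])c3ccccc3c2C(=O)c2c1c1ccccc1n2Cc1cn([C@H]2C[C@H](O)[C@@H](CO)O2)nn1` gives 280 nM

Compound 2 cannot be told apart from compound 1 on these numbers, while compound 3 stands clearly higher than both.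

The next molecule is compound 4 `O=C1c2c[n+]([O-])c3ccccc3c2C(=O)c2c1c1ccccc1n2CCN1CCCCC1`, and its difference from compound 2 is piperidin-1-yl in place of 2-(4-methylpiperazin-1-yl)ethyl on a saturated chain carbon, two bonds along the chain from an aromatic nitrogen. In words, piperidin-1-yl sits in place of 2-(4-methylpiperazin-1-yl)ethyl on a saturated chain carbon, two bonds along the chain from an aromatic nitrogen.

For the measured compounds named here, no measured step makes this same swap, so the evidence is indirect. The closest guide is a 2.3-fold higher number from compound 1 to compound 3 (0.37 log units; beyond the scatter), a modest step that also changes a group on an aromatic nitrogen. Compounds 1 and 2 also differ in that group, yet their values lie within the scatter. A modest step or none is therefore expected in this assay, and its direction is uncertain, with a slight lean towards a higher number.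

The estimated step is a 1.6-fold higher number from compound 2 to compound 4 (0.21 log units; within the scatter). The estimate for compound 4 is 130 nM, with an expected range from 45 nM to 380 nM.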

Compound 4, half-maximal inhibitory concentration: 1050 nM
Compound 4: the middle estimate sits 8.1-fold (0.91 log units) below what was measured; the whole stated range lies below it.
By their numbers in this assay, from the lowest: compounds 2 and 1 (each within the scatter of the next); then compound 3; then compound 4.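

In this assay, for the compounds shown here, the group on the aromatic nitrogen can move the number much further than the earlier compounds showed: the earlier step (a 2.3-fold higher number from compound 1 to compound 3 (0.37 log units; beyond the scatter)) was modest, while this change brings a large one (a 13-fold higher number from compound 2 to compound 4 (1.12 log units; beyond the scatter)). The change is also a double one, with 4-(4-methylpiperazin-1-yl)butyl giving way to 2-(piperidin-1-yl)ethyl, so the chain and the ring differ together. No supporting measurement bears on why the number rises so far.

Going by these compounds, it remains open whether the shorter chain, the different ring or the two together go with the rise to a higher number, which here means weaker inhibition. A 4-(piperidin-1-yl)butyl group or a 2-(4-methylpiperazin-1-yl)ethyl group on the aromatic nitrogen would separate these two parts of the change.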